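Bromophenyl amide in a shared indazolyl-indole series

The compounds below may be only part of what the source reports. "The series", "measured", "known", "first", "only" and "open" are said of these compounds alone.

Measured compounds:
compound 1 `CN(C(=O)c1ccccc1)c1ccc2[nH]c(-c3n[nH]c4ccccc34)cc2n1` — 8580 nM
compound 2 `CN(C(=O)CCc1ccccc1)c1ccc2[nH]c(-c3n[nH]c4ccccc34)cc2n1` — 7380 nM

Both compounds share one core and differ only in the group on the amide carbonyl. In a functional assay on KB cells (Homo sapiens) for antiproliferative activity, read by MTT assay, with a stated time of 72 h (a lower number here means a stronger inhibitor, a higher number a weaker inhibitor), compound 1 gives 8580 nM, and compound 2 gives 7380 nM. For the measured compounds named here, the one measured step, a 1.2-fold lower number from compound 1 to compound 2 (0.07 log units; within the scatter), exchanges phenyl for phenethyl and amounts to nothing beyond the scatter. Compound 2 thus stands lowest of the two numbers, but its nearest neighbour, compound 1, sits within the scatter of it, so no order can be claimed.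

Compound 3 `CN(C(=O)c1ccc(Br)cc1)c1ccc2[nH]c(-c3n[nH]c4ccccc34)cc2n1` is the next step from compound 2: 4-bromophenyl in place of phenethyl on a carbonyl carbon. Going by the values given here, the only step that bears on it is a 1.2-fold lower number from compound 1 to compound 2 (0.07 log units; within the scatter), since compound 3 returns to a one-ring aromatic group on the carbonyl, as in compound 1, now carrying bromine. That step was flat, and nothing measured speaks to the bromine itself. In this assay no step beyond the scatter is therefore expected; the expected step is a 1.1-fold higher number from compound 2 to compound 3 (0.04 log units; within the scatter). Compound 3 is expected to give 8000 nM, with a range from 3000 nM to 20000 nM.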

Compound 3, half-maximal inhibitory concentration: 1780 nM
For compound 3 the middle estimate is 4.5-fold (0.65 log units) above the measured one; the measured number lies below the stated range.
By their numbers in this assay, from the lowest: compound 3; then compounds 2 and 1 (each within the scatter of the next).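

The bromine is what separates these compounds: in this assay, the exchange on the carbonyl carbon that had earlier been flat is now joined by a change that moves the number, as bromo in place of hydrogen on an aromatic carbon gives a 4.8-fold lower number from compound 1 to compound 3 (0.68 log units; beyond the scatter). The exchange of phenethyl for 4-bromophenyl at the same carbonyl carbon gives a similar result, a 4.1-fold lower number from compound 2 to compound 3 (0.62 log units; beyond the scatter), so compound 3 stands apart from both earlier compounds by a modest step beyond the scatter, while those two remain within the scatter of each other. Nothing available explains why the bromine has this effect on the number.

The compounds shown leave open whether the step belongs to bromine itself or would also appear with chloro, methyl, methoxy or an amine in its place on the phenyl ring. They also leave open whether bromine on the ring of the phenethyl group of compound 2 would lower the number as it does on the phenyl group of compound 1.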